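Moving the Carboxylic Acid Around the Benzyl Ring

The source may hold more compounds than are shown below. What is called first, only, known or untested is meant among the compounds shown, and "the series" means these compounds.

Measured compounds:
compound 1, `COc1ccc(CCCCCCCCOc2ccc(CSc3cccc(C(=O)O)c3)nc2/C=C/C(=O)O)cc1`, 550 nM
compound 2, `COc1ccc(CCCCCCCCOc2ccc(CSCc3cccc(C(=O)O)c3)nc2/C=C/C(=O)O)cc1`, 131 nM

In a functional assay on the whole organism with Homo sapiens as the target, read by calcium flux (a higher number here means a weaker inhibitor, a lower number a stronger inhibitor), compound 1 gives 550 nM, while compound 2 gives 131 nM. Going by the values given here, compound 2 thus holds the lower of the two numbers, and the single measured step, a 4.2-fold lower number from compound 1 to compound 2 (0.62 log units; beyond the scatter), separates the pair by more than the scatter.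

Compound 3, `COc1ccc(CCCCCCCCOc2ccc(CSCc3ccc(C(=O)O)cc3)nc2/C=C/C(=O)O)cc1`, has not yet been measured. It differs from compound 2 by 4-carboxyphenyl in place of 3-carboxyphenyl on a saturated chain carbon bound to a sulfur, so the two are rearrangements of the same atoms. Among the compounds with values here, the one measured step concerns a different change, the insertion of a saturated carbon between the sulfur and the ring; no measured pair isolates a shift of the carboxylic acid from one ring position to another. With nothing to guide the direction, the step is expected to stay within the scatter: a 1.1-fold higher number from compound 2 to compound 3 (0.03 log units; within the scatter). Compound 3 is therefore estimated at 140 nM, with a range from 50 nM to 400 nM.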

Compound 3, half-maximal inhibitory concentration: 175 nM
For compound 3 the middle estimate is 1.3-fold (0.10 log units) below the measured one; the range from low to high includes it.
By their numbers in this assay, from the lowest: compounds 2 and 3 (each within the scatter of the next); then compound 1.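

In this assay, moving the acid from 3-carboxyphenyl to 4-carboxyphenyl on a saturated chain carbon bound to a sulfur gives a 1.3-fold higher number from compound 2 to compound 3 (0.13 log units; within the scatter), so compound 2 and compound 3 cannot be told apart and this position accepts either arrangement. The advantage over the group directly on the sulfur also survives the move, with a 3.1-fold lower number from compound 1 to compound 3 (0.50 log units; beyond the scatter), so among these compounds it is not confined to 3-carboxybenzyl. No supporting evidence bears on why the two arrangements read alike.

Going by these compounds, all three compounds carry a carboxylic acid on this ring, so it remains open whether a tetrazole or a primary amide could take its place. On these data alone, it is equally open whether a longer chain on the sulfur would keep the advantage held by compound 2 and compound 3.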